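Cyclobutyl amide in place of hydroxymethylcyclobutyl on the aminopyridine core

This account rests on a few compounds, and the source may have more. Where it says the series, first, only, none or still open, it means among the compounds named here.

Three measured compounds share the same core. Compound 1 `N#Cc1cnc(NCc2cnccc2C(F)(F)F)cc1NC[C@H]1C[C@@H](O)C1` gives 4200 nM in an assay on isolated protein for inhibition of protein kinase C delta type (Homo sapiens), read by TR-FRET, with a stated time of 2 h; a lower number here means a stronger inhibitor, a higher number a weaker inhibitor. This is the highest of the three numbers: compound 2 `CN(C)C(=O)[C@H]1CC[C@@H](Nc2cc(NCc3cnccc3C(F)(F)F)ncc2C#N)CC1` gives 1800 nM, and compound 3 `N#Cc1cnc(NCc2cncnc2-c2ccccc2)cc1N[C@H]1CC[C@@H](O)CC1` gives 90 nM, both clearly beyond the scatter relative to compound 1, so compound 1 is the weakest of the set shown.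

Compound 4 `CC1(C)[C@@H](Nc2cc(NCc3cnccc3C(F)(F)F)ncc2C#N)C[C@@H]1C(N)=O` is not yet measured. It differs from compound 1 in one place: 3-carbamoyl-2,2-dimethylcyclobutyl in place of (3-hydroxycyclobutyl)methyl on a nitrogen on an aromatic ring.

Going by the values given here, no measured pair shows this exact change. The nearest reference is compound 2 at 1800 nM, which carries its substituent directly on the ring nitrogen. A moderate gain is expected, a 2.8-fold lower number from compound 1 to compound 4 (0.45 log units; beyond the scatter), beyond the scatter but far short of compound 3. Compound 4 is thus estimated at 1500 nM, within 500 nM to 5000 nM.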

Compound 4, half-maximal inhibitory concentration: > 10000 nM
Compound 4: no number, only a limit; the forecaster's own chance of this, stated with the estimate: 5%; at least 6.6-fold (0.82 log units) between middle value and limit.
By their numbers in this assay, from the lowest: compound 3; then compound 2; then compound 1. At a limit, above all of these: compound 4.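

In this assay compound 4 reaches only a limit, > 10000 nM, not a number. Replacing (3-hydroxycyclobutyl)methyl with 3-carbamoyl-2,2-dimethylcyclobutyl gives an at least 2.3-fold higher number from compound 1 to compound 4 (0.37 log units; beyond the scatter), so keeping a four-membered ring at this position does not keep the activity. An amide alone does not set this outcome, as compound 2, which also carries one in its substituent on this nitrogen, gives 1800 nM.

The two methyl groups and the carbamoyl group enter together, so their contributions remain unseparated. A 3-carbamoylcyclobutyl without the methyl groups, or a 2,2-dimethyl-3-hydroxycyclobutyl, would separate them.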